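Hydroxyl-terminated alkoxy chain on the biphenyl series

A few compounds are considered here, and "the series" means these few. Any claim that something is new, unique, unknown or untested is made for them only; others in the source may bear on it.

Measured compounds and values:
- compound 1 `Nc1ncnc2c1nc(NCc1ccc(-c3ccncc3)cc1)n2[C@@H]1O[C@H](CO)[C@@H](O)[C@H]1O`: 2700 nM
- compound 2 `CCCOc1cc(CNc2nc3c(N)ncnc3n2[C@@H]2O[C@H](CO)[C@@H](O)[C@H]2O)ccc1-c1ccccc1`: 5200 nM
- compound 3 `CCOc1cc(-c2ccccc2)ccc1CNc1nc2c(N)ncnc2n1[C@@H]1O[C@H](CO)[C@@H](O)[C@H]1O`: 5400 nM

Of the compounds shown here, three sharing the nucleoside core have been measured in an assay on COS-7 cells for inhibition of sodium/nucleoside cotransporter 2 (Homo sapiens), read by scintillation counting; on this read-out lower numbers stand for stronger inhibition and higher numbers for weaker inhibition. Compound 1 gives 2700 nM, compound 2 gives 5200 nM and compound 3 gives 5400 nM. Compound 2 stands second highest of the three numbers; its nearest neighbour is compound 3, within the scatter, and even its furthest neighbour, compound 1, lies within the scatter. The three values therefore cannot be ordered against one another.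

The next compound, compound 4 `Nc1ncnc2c1nc(NCc1ccc(-c3ccccc3)c(OCCCCO)c1)n2[C@@H]1O[C@H](CO)[C@@H](O)[C@H]1O`, is not yet measured. It differs from compound 2 by hydroxymethyl in place of hydrogen on a saturated chain carbon, three bonds along the chain from an oxygen on an aromatic ring. Within the data shown here, no step between measured compounds isolates a change of this kind, so there is no measured precedent for it in this set.

The three measured values sit close together despite different alkoxy and aryl substituents on the benzyl side chain. On that basis a step from compound 2 to compound 4 of a 1.0-fold lower number from compound 2 to compound 4 (0.02 log units; within the scatter) is expected, that is, nothing beyond the scatter in either direction. Compound 4 is expected to give about 5000 nM in this assay, within a range from 2000 nM to 12000 nM.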

Compound 4, half-maximal inhibitory concentration: 940 nM
Compound 4: middle estimate off by 5.3-fold (0.73 log units), on the high side, and the stated range ends above it.
By their numbers in this assay, from the lowest: compound 4; then compounds 1, 2 and 3 (each within the scatter of the next).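

In this assay, the three earlier values could not be ordered, so they gave no sign that any one change on the side chain matters; the change from propyl to 4-hydroxybutyl now gives a 5.5-fold lower number from compound 2 to compound 4 (0.74 log units; beyond the scatter). Among these compounds, this is the only step available in the set, and it shows that hydroxymethyl in place of hydrogen on a saturated chain carbon, three bonds along the chain from an oxygen on an aromatic ring, is tolerated and registers as a modest gain, with compound 4 at 940 nM. No data at hand bear on what lies behind this gain.

The step adds chain length and a hydroxyl together, and without a plain butyl chain or a 3-hydroxypropyl chain in the set, the two contributions cannot be told apart. Also open, on these data alone, is how an amine or a carboxylic acid in place of the hydroxyl, or a longer chain carrying the hydroxyl, would read in this assay.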